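Chloro for methoxy in an antiproliferative series

A few compounds are considered here, and "the series" means these few. Any claim that something is new, unique, unknown or untested is made for them only; others in the source may bear on it.

Measured in a functional assay on HT-29 cells (Homo sapiens) for antiproliferative activity, read by sulforhodamine B assay, with a stated time of 48 h; on this read-out higher numbers stand for weaker inhibition and lower numbers for stronger inhibition:
Compound 1 `CCCN1CCN(c2ccc(S(=O)(=O)Oc3ccccc3CC)cc2)C1=O`: > 100000 nM (a limit of the assay)
Compound 2 `CCCN1CCN(c2ccc(S(=O)(=O)Oc3ccc(OC)cc3)cc2)C1=O`: 16000 nM

For the measured compounds named here, compound 2, at 16000 nM, holds the only true number in this assay so far. Compound 1 stands at > 100000 nM, which is a limit and not a number. Compound 3 `CCCN1CCN(c2ccc(S(=O)(=O)Oc3ccc(Cl)cc3)cc2)C1=O` has chloro in place of methoxy on an aromatic carbon, para to a large group (chloro in place of methoxy on an aromatic carbon). Going by the values given here, the one measured step, an at least 6.2-fold lower number from compound 1 to compound 2 (0.79 log units; beyond the scatter), altered the same end of the molecule and shows that changes there can move the read-out. However, that step rests on a limit and does not involve chloro. Among the compounds with values here, no measured step replaces methoxy with chloro, so no direction is supported, and no shift beyond the scatter is expected. The estimated step is a 1.3-fold higher number from compound 2 to compound 3 (0.10 log units; within the scatter). Compound 3 is expected at 20000 nM, within an estimated range of 5000 nM to 80000 nM.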

Compound 3, half-maximal inhibitory concentration: 15000 nM
The estimate for compound 3 lay 1.3-fold (0.12 log units) above the measured number; measured number inside the range.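

In this assay, chloro in place of methoxy on an aromatic carbon, para to a large group, gives a 1.1-fold lower number from compound 2 to compound 3 (0.03 log units; within the scatter), so at this position the two groups cannot be told apart on this read-out. With 4-chlorophenyl in place of 2-ethylphenyl on an oxygen, the result is an at least 6.6-fold lower number from compound 1 to compound 3 (0.82 log units; beyond the scatter), which means that two different groups now stand clear of compound 1 and the earlier gap is no longer tied to methoxy alone. Compound 1 stands at a limit and not at a number: the limit of > 100000 nM in this assay, at which 1 of the 3 values shown sits.

From the compounds shown here alone, whether an amine or a carboxylic acid on the same carbon would stay level with methoxy and chloro remains open. The compounds shown also do not separate the identity of the ethyl group from its place on the ring.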